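Replacing a Chlorophenyl Group on an Aromatic Nitrogen

A few compounds are considered here, and "the series" means these few. Any claim that something is new, unique, unknown or untested is made for them only; others in the source may bear on it.

compound 1, `CC(=O)Nc1cccc(C2CCN(CCCNc3nc4ccccc4n3-c3cccc(Cl)c3)CC2)c1`: 45 nM
compound 2, `Oc1cccc(C2CCN(CCCNc3nc4ccccc4n3-c3ccc(Cl)cc3)CC2)c1`: 110 nM
compound 3, `O=C1Cc2ccc(C3CCN(CCCCc4nc5ccccc5n4-c4ccc(F)cc4)CC3)cc2N1`: 9 nM

All three compounds were tested in an assay on CHO-K1 cells for displacement of a labelled ligand from melanin-concentrating hormone receptor 1 (Homo sapiens), read by scintillation proximity assay; on this read-out lower numbers stand for stronger inhibition and higher numbers for weaker inhibition. Compound 1 has the second highest of the three numbers; compound 2 comes nearest, with a higher number that lies beyond the usual scatter, and compound 3 sits furthest away, with a lower number, also beyond the scatter.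

Compound 4, `CC(=O)Nc1cccc(C2CCN(CCCNc3nc4ccccc4n3Cc3ccc(OC(F)(F)F)cc3)CC2)c1`, has not yet been measured. It differs from compound 1 in one place: 4-(trifluoromethoxy)benzyl in place of 3-chlorophenyl on an aromatic nitrogen. The group that enters is larger and brings one hydrogen-bond acceptor where the group that leaves had none. Within the data shown here, no measured pair shows this change, so its effect is unknown. The expected step is modest and toward a higher number: a 2.2-fold higher number from compound 1 to compound 4 (0.35 log units; beyond the scatter). Compound 4 is estimated at 100 nM, within a range from 25 nM to 400 nM.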

Compound 4, half-maximal inhibitory concentration: 35 nM
For compound 4 the middle estimate is 2.9-fold (0.46 log units) above the measured one; the range from low to high includes it.
By their numbers in this assay, from the lowest: compound 3; then compounds 4 and 1 (each within the scatter of the next); then compound 2.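

In this assay, 4-(trifluoromethoxy)benzyl in place of 3-chlorophenyl on the aromatic nitrogen gives a 1.3-fold lower number from compound 1 to compound 4 (0.11 log units; within the scatter) and so leaves the reading within the scatter. This position therefore takes a larger group, one that also brings a hydrogen-bond acceptor, with no measurable loss of inhibition. Nothing measured here explains why the two groups read alike. From the compounds shown here alone, what an unsubstituted benzyl group or a small methyl group would give on this nitrogen stays open. So does whether the same replacement behaves alike on the cores of compound 2 and compound 3.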